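Methoxy for chloro on the aryl ring: notes toward compound 4

The compounds below may be only part of what the source reports. "The series", "measured", "known", "first", "only" and "open" are said of these compounds alone.

Measured so far in a functional assay on the whole organism (strain albino) for inhibition, with Rattus norvegicus as the target, read by paw edema, with stated times of 30 min and 5 h, at a dose of 100 mg/kg by the oral route; on this read-out lower numbers stand for less inhibition and higher numbers for more inhibition at the one dose given (going by the name of the read-out):
- compound 1 `COc1ccc(/C=C/C(=O)c2ccc(NC(=O)CBr)cc2)cc1` gives 34%
- compound 2 `COc1ccc(/C=C/C(=O)c2ccc(NC(=O)CO[N+](=O)[O-])cc2)cc1` gives 46%
- compound 3 `CC(=O)c1ccc(OCC(=O)Nc2ccc(C(=O)/C=C/c3ccc(Cl)cc3)cc2)cc1` gives 55%

Compound 3 stands with its inhibition beyond the scatter above compound 1 and within the scatter of compound 2. Going by the values given here, the only single-site step among the measured compounds is a number 12 percentage points higher from compound 1 to compound 2 (beyond the scatter); it concerns the saturated chain carbon of the acetamide, not the aromatic ring, and so does not bear directly on the change considered here.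

Compound 4 `COc1ccc(/C=C/C(=O)c2ccc(NC(=O)COc3ccc(C(C)=O)cc3)cc2)cc1` differs from compound 3 as follows: methoxy in place of chloro on an aromatic carbon. Among the compounds with values here, no measured pair isolates this change. Compounds 1 and 2 carry the methoxy and compound 3 the chloro, but they differ at the amide as well, so their values show only that all three fall within a narrow band and that the methoxy bearers are not set apart from compound 3 by more than the observed spread. Within the data shown here, with no step bearing on the ring substituent, no shift beyond the scatter is expected in this assay : the step of a number 5 percentage points lower from compound 3 to compound 4 (within the scatter) is estimated to lie within it. Compound 4 is therefore expected to give about 50% in this assay , with a range from 35% to 65%.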

Compound 4, a percentage reported as inhibition, in the whole organism at one dose (the size of the read-out at that dose, not a potency): 30%
Compound 4: middle estimate off by 20 percentage points, on the high side; the whole stated range lies above it.
By their numbers in this assay, from the lowest: compounds 4 and 1 (each within the scatter of the next); then compounds 2 and 3 (each within the scatter of the next).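

In this assay, going by these compounds alone, methoxy in place of chloro, the change from 4-chlorophenyl to 4-methoxyphenyl, gives a number 25 percentage points lower from compound 3 to compound 4 (beyond the scatter), the first single-site reading at this aromatic carbon, and it shows that the substituent here counts in this read-out at the one dose given. With the methoxy held constant, 4-acetylphenoxy in place of bromo gives a number 4 percentage points lower from compound 1 to compound 4 (within the scatter), while 4-acetylphenyl in place of nitro on the oxygen gives a number 16 percentage points lower from compound 2 to compound 4 (beyond the scatter), so among the three methoxy compounds the nitrooxy chain of compound 2 alone stands apart. Nothing at hand accounts for the step at the aromatic carbon.

As far as these compounds go, whether the gap between chloro and methoxy carries over to the bromo or nitrooxy chains remains open, as a single pair reads it, on the 4-acetylphenoxy chain alone. Also open, from the compounds shown here alone, is how a hydroxy or a dimethylamino group on the same aromatic carbon would compare with chloro and methoxy, and whether any of these steps would hold at another dose in this assay.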